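The source may hold more compounds than are shown below. What is called first, only, known or untested is meant among the compounds shown, and "the series" means these compounds.

Measured compounds:
compound 1 `C=CCNc1n[n+]([O-])c2ccccc2[n+]1[O-]` — in a functional assay on K562 cells (Homo sapiens) for cytotoxicity, read by MTT assay, with a stated time of 48 h (on this read-out lower numbers stand for stronger inhibition and higher numbers for weaker inhibition), compound 1 gives 11200 nM
compound 2 `[O-][n+]1nc(NCc2ccccc2)[n+]([O-])c2ccccc21` — compound 2 gives 1900 nM
compound 3 `CCN(CC)c1n[n+]([O-])c2ccccc2[n+]1[O-]` — compound 3 gives > 55000 nM, which is a limit of the assay and not a number.

Among the numbers given, compound 1 stands highest of the two; its nearest neighbour is compound 2, reached by a 5.9-fold lower number from compound 1 to compound 2 (0.77 log units; beyond the scatter). Compound 3 is known only through the limit (the limit of > 55000 nM in this assay, at which 1 of the 3 values shown sits).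

Compound 4 `[O-][n+]1nc(Nc2ccccc2)[n+]([O-])c2ccccc21` is the next member. Relative to compound 1 the change is phenyl in place of allyl on a nitrogen on an aromatic ring; the phenyl thus enters on the nitrogen on the aromatic ring, where in compound 2 it entered on a saturated chain carbon bound to that nitrogen.

Among the measured compounds shown here, two measured steps bear on this. The step of a 5.9-fold lower number from compound 1 to compound 2 (0.77 log units; beyond the scatter) shows phenyl in place of vinyl giving a lower number. The step of an at least 4.9-fold higher number from compound 1 to compound 3 (0.69 log units; beyond the scatter) shows diethylamino in place of allylamino giving a higher number; compound 4 does not carry diethylamino, so that step argues neither way. A modest lowering is therefore expected, smaller than for compound 2 since no chain separates the phenyl from the nitrogen. Compound 4 is expected at 4500 nM, within 1500 nM to 14000 nM. The expected step is a 2.5-fold lower number from compound 1 to compound 4 (0.40 log units; beyond the scatter).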

Compound 4, half-maximal inhibitory concentration: 2400 nM
The estimate for compound 4 lay 1.9-fold (0.27 log units) above the measured number, and the stated range covers the measured number.
By their numbers in this assay, from the lowest: compounds 2 and 4 (each within the scatter of the next); then compound 1. At a limit, above all of these: compound 3.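

Phenyl in place of allyl on the nitrogen on an aromatic ring gives a 4.7-fold lower number from compound 1 to compound 4 (0.67 log units; beyond the scatter) and so shows that the lowering seen with phenyl does not need a saturated chain carbon on that nitrogen. In this assay, among the compounds shown here, compound 2 gives 1900 nM and compound 4 gives 2400 nM and these two values lie within the scatter of each other, so that chain carbon brings no separation in this pair. Nothing shown gives a reason for the step from allyl to phenyl.

As far as these compounds go, whether a longer chain carrying the phenyl on the nitrogen, or a methoxy group on the phenyl, would move the number stays open. From the compounds shown here alone, compound 3 is known only as a limit of the assay, and what a single ethyl on that nitrogen would give also stays open.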